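A few compounds are considered here, and "the series" means these few. Any claim that something is new, unique, unknown or untested is made for them only; others in the source may bear on it.

In a functional assay on A549 cells (Homo sapiens) for cytotoxicity (a higher number here means a weaker inhibitor, a lower number a stronger inhibitor), compound 1 `C=C/C=C\[C@H](C)[C@H](OC(N)=O)[C@@H](C)[C@H](O)[C@@H](C)C/C(C)=C\[C@H](C)[C@@H](O)[C@@H](C)/C=C\CCc1ccc(C)c(O)c1` gives 4000 nM and compound 2 `C=C/C=C\[C@H](C)[C@H](OC(N)=O)[C@@H](C)[C@H](O)[C@@H](C)C/C(C)=C\[C@H](C)[C@@H](O)[C@@H](C)/C=C\CCc1cccc(Cl)c1` gives 580 nM, the lower of the two numbers. Compound 3 `C=C/C=C\[C@H](C)[C@H](OC(N)=O)[C@@H](C)[C@H](O)[C@@H](C)C/C(C)=C\[C@H](C)[C@@H](O)[C@@H](C)/C=C\CCc1cc(F)cc(F)c1` keeps the shared core and changes one group: 3,5-difluorophenyl in place of 3-chlorophenyl on a saturated chain carbon, two bonds along the chain from a double-bonded chain carbon. Within the data shown here, the only measured step that bears on this is a 6.9-fold lower number from compound 1 to compound 2 (0.84 log units; beyond the scatter), where 3-chlorophenyl took the place of 3-hydroxy-4-methylphenyl. It shows that this group can move the number, but neither compound in it carries fluorine, so it sets no direction. In this assay, a small move is expected, estimated as a 1.2-fold higher number from compound 2 to compound 3 (0.08 log units; within the scatter). The expected value for compound 3 is 700 nM, within a range of 250 nM to 2000 nM.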

Compound 3, half-maximal inhibitory concentration: 1000 nM
The estimate for compound 3 lay 1.4-fold (0.15 log units) below the measured number; measured number inside the range.
By their numbers in this assay, from the lowest: compounds 2 and 3 (each within the scatter of the next); then compound 1.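

In this assay, two fluorines in place of one chlorine on the ring make no clear difference (a 1.7-fold higher number from compound 2 to compound 3 (0.24 log units; within the scatter)), so compound 2 and compound 3 cannot be told apart. The second halogen-bearing ring also gives a lower number than the 3-hydroxy-4-methylphenyl group (a 4.0-fold lower number from compound 1 to compound 3 (0.60 log units; beyond the scatter)), so this drop is not specific to chlorine. Nothing available explains why these groups behave this way. Still open, as far as these compounds go, is how a ring carrying an amine or a carboxylic acid would behave here. Also open, from the compounds shown here alone, is what a longer chain between the double bond and the ring would do.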